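Second chloro on two cores: one step known, one expected

A few compounds are considered here, and "the series" means these few. Any claim that something is new, unique, unknown or untested is made for them only; others in the source may bear on it.

Compound 1 `COc1ccc(N(C)c2ncnc3c2ncn3C)cc1` and compound 2 `COc1ccc(N(C)c2nc(Cl)nc3c2ncn3C)cc1` share one core. In a functional assay on AGS cells (Homo sapiens) for antiproliferative activity, read by MTT assay, with a stated time of 48 h (on this read-out higher numbers stand for weaker inhibition of growth and lower numbers for stronger inhibition of growth), compound 1 gives > 100000 nM, which is a limit of the assay and not a number. Compound 2 gives 260 nM in this assay. The change is chloro in place of hydrogen on an aromatic carbon, and the step is an at least 380-fold lower number from compound 1 to compound 2 (2.58 log units; beyond the scatter). The limit sits at the limit of > 100000 nM in this assay, at which 2 of the 3 values shown sit, so the true size of this step is not known, only its lower bound.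

Compound 3 `COc1ccc(Cn2cnc3c(Cl)ncnc32)cc1OC` has a different core; the difference between the two cores is not broken down here. In this assay compound 3 gives > 100000 nM, a limit of the assay and not a number.

Compound 4 `COc1ccc(Cn2cnc3c(Cl)nc(Cl)nc32)cc1OC` is not yet measured. It differs from compound 3 by chloro in place of hydrogen on an aromatic carbon. The surroundings are not identical to the earlier case: here the new chloro stands meta to a chloro group, whereas in compound 2 it stands meta to a large group, so this is the same kind of change, not the same change. From compound 3 to compound 4 a step of an at least 20-fold lower number from compound 3 to compound 4 (1.30 log units; beyond the scatter) is expected, resting on the measured step from compound 1 to compound 2 in this assay. For compound 4 the estimate is 5000 nM, within 500 nM to 100000 nM.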

Compound 4, concentration for 50% growth inhibition: 11000 nM
The estimate for compound 4 lay 2.2-fold (0.34 log units) below the measured number, and the stated range covers the measured number.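

In this assay, chloro in place of hydrogen on an aromatic carbon moves the number in the same direction on the second core, with an at least 9.0-fold lower number from compound 3 to compound 4 (0.95 log units; beyond the scatter). The direction of the change therefore holds on both cores shown, but two cores are a small basis, and no size can be carried from one to the other: the same change on two cores in this assay, an at least 380-fold lower number (2.58 log units; beyond the scatter) from compound 1 to compound 2 and an at least 9.0-fold lower number (0.95 log units; beyond the scatter) from compound 3 to compound 4; the limit leaves it open whether they differ Each step is only a lower bound, as each starts from a compound that sits at the assay limit: the limit of > 100000 nM in this assay, at which 2 of the 4 values shown sit.

Open, from the compounds shown here alone, is whether the step on the core of compound 3 depends on the chloro group that stands meta to the new chloro, a feature the core of compound 1 does not share. Also open, going by these compounds, is whether an amine, a nitrile or a longer chain in place of the new chloro would move the number in the same way on either core.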